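Diarylheptanoid-free triformylphloroglucinol meroterpenoids: stereo-undefined analogue

The compounds below may be only part of what the source reports. "The series", "measured", "known", "first", "only" and "open" are said of these compounds alone.

Measured so far:
- compound 1, `CC(=O)CC[C@@H]1[C@H]([C@H]2C(=O)CC[C@]2(C)[C@H](CC(C)C)c2c(O)c(C=O)c(O)c(C=O)c2O)C1(C)C`. In a functional assay on A549 cells (Homo sapiens) for cytotoxicity, read by sulforhodamine B assay, with a stated time of 72 h (a lower number here means a stronger inhibitor, a higher number a weaker inhibitor), compound 1 gives < 10000 nM, a limit of the assay rather than a number.
- compound 2, `CC(C)CC(c1c(O)c(C=O)c(O)c(C=O)c1O)C1CC[C@@H](C)C2=C[C@H](C(C)(C)O)CC[C@]21C`. In this assay compound 2 gives < 10000 nM, again a limit.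
- compound 3, `CC(C)C[C@H](c1c(O)c(C=O)c(O)c(C=O)c1O)[C@@]1(C)CC[C@H]2C1=C[C@H](C(C)(C)O)CC[C@H]2C`. In this assay compound 3 gives < 10000 nM, also a limit.

For the measured compounds named here, compound 3 therefore stands nowhere distinct: all three values sit at the same limit (the limit of < 10000 nM in this assay, at which 3 of the 3 values shown sit), and no step between them can be sized. Compound 4, `CC(C)CC(c1c(O)c(C=O)c(O)c(C=O)c1O)[C@@]1(C)CC[C@H]2C1=C[C@H](C(C)(C)O)CC[C@H]2C`, differs from compound 3 only in this: the two compounds have the same atoms and bonds; at least one stereo element is drawn with a configuration in one of them and without one in the other: 1 of 5 stereo elements differ; a stereocentre at a saturated chain carbon is drawn S in compound 3 and without a configuration in compound 4. With the atoms and bonds unchanged, no step beyond the scatter is expected in this assay, in either direction. Compound 4 is expected to give 5000 nM (range 1500 nM to 12000 nM), a step from compound 3 of a step that the limit leaves unreadable from compound 3 to compound 4, and most likely again only a limit.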

Compound 4, half-maximal inhibitory concentration: < 10000 nM
Compound 4 was reported as a limit; the forecaster's own chance of this, stated with the estimate: 70%; the middle value is on the limit's open side.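

No step can be read between compound 3 and compound 4, as both values are limits: the limit of < 10000 nM in this assay, at which 4 of the 4 values shown sit. The compounds shown leave open how far each lies from that limit, and whether the configuration at the saturated chain carbon matters.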